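This account rests on a few compounds, and the source may have more. Where it says the series, first, only, none or still open, it means among the compounds named here.

Measured compounds in the series:

compound 1, `Cc1cc(C2CCC2)c(S(C)(=O)=O)cc1C(=O)N=C(N)N`: in a functional assay for inhibition of sodium/hydrogen exchanger (Oryctolagus cuniculus) (a higher number here means a weaker inhibitor, a lower number a stronger inhibitor), compound 1 gives 8.2 nM
compound 2, `Cc1cc(Sc2ccccc2Cl)c(S(C)(=O)=O)cc1C(=O)N=C(N)N`: in this assay compound 2 gives 14 nM
compound 3, `Cc1cc(Oc2ccc(Cl)cc2)c(S(C)(=O)=O)cc1C(=O)N=C(N)N`: in this assay compound 3 gives 13 nM

Compound 3 holds the second highest of the three numbers. Its nearest neighbour is compound 2, a 1.1-fold lower number from compound 2 to compound 3 (0.03 log units; within the scatter); the furthest is compound 1, a 1.6-fold higher number from compound 1 to compound 3 (0.20 log units; within the scatter). Every step among the three falls within the scatter, so the three measured compounds cannot be ordered against one another.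

The next compound is compound 4, `Cc1cc(C(F)(F)F)c(S(C)(=O)=O)cc1C(=O)N=C(N)N`. The change from compound 3 is trifluoromethyl in place of 4-chlorophenoxy on an aromatic carbon.

All three measured steps concern exchanges of the group on this same aromatic carbon: a 1.7-fold higher number from compound 1 to compound 2 (0.23 log units; within the scatter), a 1.6-fold higher number from compound 1 to compound 3 (0.20 log units; within the scatter) and a 1.1-fold lower number from compound 2 to compound 3 (0.03 log units; within the scatter). None of them moved the number beyond the scatter, whether the group carried a ring or not. Within the data shown here, no measured compound carries trifluoromethyl, so the step to compound 4 is not covered directly. On the evidence of the three steps, no step beyond the scatter is expected in this assay, in either direction, though the range is kept wide to allow for the unmeasured group.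

For compound 4 the expected result in this assay is 12 nM, with a range from 4 nM to 40 nM. This estimate means a 1.1-fold lower number from compound 3 to compound 4 (0.03 log units; within the scatter).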

Compound 4, half-maximal inhibitory concentration: 37 nM
Compound 4: middle estimate off by 3.1-fold (0.49 log units), on the low side, and the stated range covers the measured number.
By their numbers in this assay, from the lowest: compounds 1, 3 and 2 (each within the scatter of the next); then compound 4.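

In this assay, among these compounds, the aromatic carbon ortho to the methylsulfonyl group proves not to be indifferent to its substituent: trifluoromethyl is the first group here to take the number beyond the scatter, with a 2.8-fold higher number from compound 3 to compound 4 (0.45 log units; beyond the scatter) and a 2.6-fold higher number from compound 2 to compound 4 (0.42 log units; beyond the scatter) and also a 4.5-fold higher number from compound 1 to compound 4 (0.65 log units; beyond the scatter). Among these four compounds, the three groups that stay within the scatter of one another all carry a ring, while trifluoromethyl has none, and no compound shown goes against this association; cyclobutyl keeps compound 1 with compound 2 and compound 3, so a six-membered aromatic ring is not required to stay in that group. No measurement available gives a reason for the shift.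

Going by these compounds, whether the separation follows the absence of a ring or belongs to trifluoromethyl itself remains open, and a plain methyl, an ethyl chain, a methoxy group, a lone chlorine or an amine on this carbon would help to separate the two readings. Also open, on these data alone, is whether a directly attached phenyl or a cyclopentyl group would stay with compound 1, compound 2 and compound 3.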